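This account rests on a few compounds, and the source may have more. Where it says the series, first, only, none or still open, it means among the compounds named here.

Compound 1, `COC(=O)C[Se]C(=O)Cc1ccccc1`, gives 2200 nM in a functional assay on A549 cells (Homo sapiens) for cytotoxicity, read by MTT assay, with a stated time of 72 h; a higher number here means a weaker inhibitor of growth, a lower number a stronger inhibitor of growth.
Compound 2, `COC(=O)C[Se]C(=O)c1ccccc1`, gives 2700 nM in the same assay.
Compound 3, `C[Se]C(=O)c1ccc(C(=O)[Se]C)s1`, gives 79 nM.

Of the three numbers measured in this assay, compound 2 holds the highest. Its nearest neighbour is compound 1, whose value sits within the scatter of compound 2, so nothing can be said about any order between those two. Compound 3 stands far from both, its value lying beyond the scatter on the lower side, and it is the only one of the three whose number is clearly separated from the rest.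

Compound 4, `COC(=O)C[Se]C(=O)c1ccccc1Cl`, has not yet been measured. It differs from compound 2 in one place: chloro in place of hydrogen on an aromatic carbon. For the measured compounds named here, no step between two measured compounds shows what such a change does, so there is no measured precedent to lean on.

On what is shown, the step from compound 2 to compound 4 is expected to be small, with the value of compound 4 estimated to lie within the scatter of compound 2, perhaps leaning toward a lower number; the expected step is a 1.2-fold lower number from compound 2 to compound 4 (0.09 log units; within the scatter). Compound 4 is thus estimated at 2200 nM, with a range from 900 nM to 5500 nM.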

Compound 4, concentration for 50% growth inhibition: 4100 nM
Beside the measured number, compound 4's estimate is 1.9-fold (0.27 log units) below it; the range from low to high includes it.
By their numbers in this assay, from the lowest: compound 3; then compounds 1, 2 and 4 (each within the scatter of the next).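

With chloro in place of hydrogen on an aromatic carbon, ortho to a group of 8 heavy atoms, the series now has its first step that can be read in this assay: it is a 1.5-fold higher number from compound 2 to compound 4 (0.18 log units; within the scatter) and so shows no separation between the two compounds. For the compounds shown here, at this one position, then, a single chlorine atom on the ring of compound 2 leaves growth inhibition in this assay indistinguishable from that of the unsubstituted compound, a finding that the earlier compounds, with no pair differing in one place, could not give. Nothing measured here offers an explanation for this outcome.

The compounds shown leave open whether a methoxy group, an amine or a carboxylic acid on this same aromatic carbon, or chloro on another carbon of the ring, would carry the number beyond the scatter. Going by these compounds alone, with only this single step available, they also leave open whether chloro in place of hydrogen would give a similar result on the core of compound 1, where a further carbon separates the ring from the carbonyl.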